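Replacing one side group of compound 1

The source may report more compounds than this note shows. Statements on the series, on what has been measured and on what is new or still open speak of the compounds shown alone.

compound 1 `CCc1cccc2c(OC)c(-c3occ(C)c3C(=S)OC)ccc12` gives 6.2 ug/mL
compound 2 `CCc1cccc2c(OC(C)=O)c(-c3occ(C)c3COC(C)=O)ccc12` gives > 10 ug/mL

Among the measured compounds shown here, in a functional assay on A549 cells (Homo sapiens) for cytotoxicity, read by MTT assay, with a stated time of 72 h (on this read-out higher numbers stand for an effect only at larger amounts of compound and lower numbers for an effect already at smaller amounts), compound 1 gives 6.2 ug/mL as the only actual number so far, so it is the single firm reference point. Compound 2 is reported as > 10 ug/mL and this is a limit of the assay, not a number.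

Compound 3 `CCc1cccc2c(OC)c(-c3occ(C)c3COCC(F)(F)F)ccc12` keeps the core of compound 1 and alters one place, on an aromatic carbon of a five-membered aromatic ring with 1 oxygen. The change is a group of 7 heavy atoms (3 carbon, 1 oxygen, 3 fluorine; no ring) in place of a group of 4 heavy atoms (2 carbon, 1 oxygen, 1 sulfur; no ring), on an aromatic carbon and the group that enters is (2,2,2-trifluoroethoxy)methyl.

For the measured compounds named here, no measured pair of compounds shows what a single change does here, so any forecast rests on very little. The a 1.3-fold higher number from compound 1 to compound 3 (0.11 log units; within the scatter) expected in this assay is small, leaning toward a higher number, and it is expected to stay within the usual scatter. Compound 3 is estimated at 8 ug/mL with an expected range from 3.5 ug/mL to 18 ug/mL in this measurement.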

Compound 3, concentration for half-maximal effect: > 10 ug/mL
Compound 3 was reported as a limit (the forecaster's own chance of this, stated with the estimate: 35%); at least 1.2-fold (0.09 log units) between middle value and limit.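

Among the compounds shown here, with the rest of the core of compound 1 kept, placing (2,2,2-trifluoroethoxy)methyl on this aromatic carbon of the five-membered ring, in place of the side group of compound 1, gives the first single-place comparison at this position in this assay, with an at least 1.6-fold higher number from compound 1 to compound 3 (0.20 log units; that floor lies within the scatter). Compound 3 is reported as > 10 ug/mL, which is a limit of the assay and not a number. The step is therefore only a floor: the change does not bring the value down to a measured number, but the true gap may be small or large, and the reading stops at the same point as for most of the series: the limit of > 10 ug/mL in this assay, at which 2 of the 3 values shown sit.

As far as these compounds go, how far the value of compound 3 lies past that limit remains open, so this one change cannot be sized. Also open, from the compounds shown here alone, is whether a different group on this same carbon, such as an amine, a carboxylic acid or a simple hydroxymethyl, would give a measurable number in this assay.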